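A Piperazine Amide Series Tested on Leukaemia Cells

This account rests on a few compounds, and the source may have more. Where it says the series, first, only, none or still open, it means among the compounds named here.

Measured so far:
compound 1 `CCc1nc(-c2ccc(C(C)(C)C)cc2)c(C(=O)N2CCN(c3cccc(OC)c3)CC2)o1`: "not active" (no number reported)
compound 2 `C=C(C)c1ccc(N2CCN(C(=O)c3oc(C)nc3-c3ccccc3)CC2)cc1`: "not active" (no number reported)
compound 3 `CCc1nc(-c2ccc(F)cc2)c(C(=O)N2CCN(c3cccc(Cl)c3)CC2)o1`: 169 nM

All three compounds were tested in a functional assay on HL-60 cells (Homo sapiens) for inhibition, read by MTT assay, with a stated time of 72 h; a lower number here means a stronger inhibitor, a higher number a weaker inhibitor. For the measured compounds named here, compound 3 is the only one with a number; in this assay compound 3 gives 169 nM. Compound 2 stands without a number: in this assay compound 2 gives "not active" (no number reported), and compound 1 is the second entry of that kind, so compound 2 cannot be placed on a scale against compound 3.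

Compound 4 `Cc1nc(-c2ccccc2)c(C(=O)N2CCN(c3ccccc3C(F)(F)F)CC2)o1` has not been measured. It differs from compound 2 in one place: 2-(trifluoromethyl)phenyl in place of 4-(1-methylethenyl)phenyl on an amine nitrogen in a ring. Going by the values given here, no step between measured compounds is known, and compound 2 has no number, so the size of the step to compound 4 in this assay cannot be taken from the data; a move to a measurable value is possible, but a result without a number is at least as likely. Compound 4 is estimated at 6000 nM, within 1500 nM to 30000 nM.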

Compound 4, half-maximal inhibitory concentration: 120 nM
Beside the measured number, compound 4's estimate is 50-fold (1.70 log units) above it, outside the stated range (below it).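

In this assay, for the compounds shown here, compound 2 has no number, so no step from compound 2 to compound 4 can be read. No measured evidence bears on this result. The compounds shown leave open how much swapping 4-(1-methylethenyl)phenyl for 2-(trifluoromethyl)phenyl changes activity.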